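Anilide series: methoxy for methyl on the benzamide ring

A few compounds are considered here, and "the series" means these few. Any claim that something is new, unique, unknown or untested is made for them only; others in the source may bear on it.

Measured so far:
compound 1 `COc1cccc(OCC(=O)Nc2cccc(NC(=O)c3ccc(N(C)C)cc3)c2)c1`: > 10000 nM
compound 2 `Cc1ccc(C(=O)Nc2cccc(NC(=O)COc3ccc4c(=O)ccoc4c3)c2)cc1`: 183 nM

Compound 1 `COc1cccc(OCC(=O)Nc2cccc(NC(=O)c3ccc(N(C)C)cc3)c2)c1` gives only a limit in an assay on isolated protein for inhibition of Rho-associated protein kinase 1 (Homo sapiens), read by scintillation counting, radiometric assay and 33P incorporation, with a stated time of 40 min, in the presence of a further agent that is not named here (a higher number here means a weaker inhibitor, a lower number a stronger inhibitor), namely > 10000 nM, so no number is known for it; it sits at the limit of > 10000 nM in this assay, at which 1 of the 2 values shown sits. Among the compounds with values here, compound 2 `Cc1ccc(C(=O)Nc2cccc(NC(=O)COc3ccc4c(=O)ccoc4c3)c2)cc1` is the one compound with a measured number, this assay giving 183 nM. The two values differ in more than one place, so their gap is read only as what the two values show.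

Compound 3 `COc1ccc(C(=O)Nc2cccc(NC(=O)COc3ccc4c(=O)ccoc4c3)c2)cc1` is not yet measured. It differs from compound 2 by methoxy in place of methyl on an aromatic carbon, para to a large group, so that 4-methylphenyl becomes 4-methoxyphenyl on the carbonyl side of the shared core. Within the data shown here, no measured pair isolates this change, so the size of the step rests on the change alone. The expected step is a 1.2-fold higher number from compound 2 to compound 3 (0.08 log units; within the scatter), not beyond the usual scatter. Compound 3 is therefore estimated at 220 nM in this assay, within a range from 70 nM to 700 nM.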

Compound 3, half-maximal inhibitory concentration: 18 nM
Beside the measured number, compound 3's estimate is 12-fold (1.09 log units) above it; measured number below the stated range.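

In this assay, within the data shown here, methoxy in place of methyl on an aromatic carbon, para to a large group, gives a 10-fold lower number from compound 2 to compound 3 (1.01 log units; beyond the scatter) and this is the first step that isolates a single change. The earlier values could not show that this position responds to what it carries, since those two compounds differ in more than one place; here the rest of the structure is held constant and a step beyond the scatter remains, with one oxygen and one hydrogen-bond acceptor the only additions counted. No measurement shown gives a cause for the size of this step.

On these data alone, whether a hydroxyl, an ethoxy or a fluorine in the same place would track with methoxy or with methyl stays open, as does whether methoxy elsewhere on this ring would give a step of similar size. Compound 1 gives the limit > 10000 nM and differs from the other two compounds in more than one place, so it cannot settle either question.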